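Para-halo amide variation on a thiazole carboxamide series

A few compounds are considered here, and "the series" means these few. Any claim that something is new, unique, unknown or untested is made for them only; others in the source may bear on it.

Measured so far:
- compound 3 `CN1CCN(c2ccc(Nc3nc(-c4cccc(NC(=O)c5ccc(F)cc5)c4)sc3C(N)=O)cc2)CC1`: 1420 nM
- compound 1 `CCOC(=O)c1sc(-c2cccc(NC(=O)c3ccc(C(F)(F)F)cc3)c2)nc1Nc1ccc(N2CCN(C)CC2)cc1`: "not determined" (no result reported)
- compound 2 `CCOC(=O)c1sc(-c2cccc(NC(=O)c3ccc(F)cc3)c2)nc1Nc1ccc(N2CCN(C)CC2)cc1`: "not determined" (no result reported)

Going by the values given here, in a functional assay on Ramos cells (Homo sapiens) for antiproliferative activity, read by CCK-8 assay, with a stated time of 72 h (on this read-out higher numbers stand for weaker inhibition and lower numbers for stronger inhibition), compound 3 gives 1420 nM, the only number available for the series. Among the compounds with values here, of the ethyl ester analogues, compound 1 gives "not determined" (no result reported) and compound 2 gives "not determined" (no result reported) in this assay, so no step between measured compounds can be read.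

Compound 4 `CN1CCN(c2ccc(Nc3nc(-c4cccc(NC(=O)c5ccc(Cl)cc5)c4)sc3C(N)=O)cc2)CC1` differs from compound 3 by chloro in place of fluoro on an aromatic carbon. Within the data shown here, with no measured step to anchor it, the change is expected to fall within the usual scatter: a 1.3-fold lower number from compound 3 to compound 4 (0.11 log units; within the scatter) is the estimated step from compound 3 to compound 4, with no direction claimed beyond scatter. Compound 4 is therefore expected to give about 1100 nM in this assay, within a range of 400 nM to 3000 nM.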

Compound 4, half-maximal inhibitory concentration: 1360 nM
Compound 4: the middle estimate sits 1.2-fold (0.09 log units) below what was measured, within the range that was stated.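

In this assay, going by these compounds alone, the first readable step is a 1.0-fold lower number from compound 3 to compound 4 (0.02 log units; within the scatter), so at this position on the benzoyl amide, 4-fluorophenyl and 4-chlorophenyl are not told apart. The result therefore gives this exchange no measurable weight in the read-out. Nothing available bears on the result beyond the values themselves.

Steps involving the ethyl esters, compound 1 and compound 2, cannot be read, which leaves trifluoromethyl at this position without a number. Also open, going by these compounds, is how an amine, a methoxy group or a carboxylic acid would read here in place of the halogen.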